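A few compounds are considered here, and "the series" means these few. Any claim that something is new, unique, unknown or untested is made for them only; others in the source may bear on it.

Compound 1 `C=C(c1ccc(OC)cc1NC(=O)CO)c1ccc(OC)c2c1OC(C)(C)C=C2` is a diaryl alkene whose aniline nitrogen carries a hydroxyacetyl amide. In a functional assay on A2780 cells (Homo sapiens) for antiproliferative activity, read by MTT assay, with a stated time of 48 h (a lower number here means a stronger inhibitor, a higher number a weaker inhibitor), compound 1 gives 40 nM. Compound 3 `C=C(c1ccc(OC)cc1NC(=O)CN)c1ccc(OC)c2c1OC(C)(C)C=C2` keeps everything else and differs from compound 1 only in that (amino in place of hydroxy on a saturated chain carbon bound to a carbonyl carbon); in this assay compound 3 gives 80 nM, so the change made a 2.0-fold higher number from compound 1 to compound 3 (0.30 log units; within the scatter).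

Compound 2 `C=C(c1cc(OC)c(OC)c(OC)c1)c1ccc(OC)cc1NC(=O)CO` carries the same hydroxyacetyl amide on a different core, and how its core differs from that of compound 1 is not broken down here. In this assay compound 2 gives 30 nM, a number within the scatter of compound 1.

Compound 4 `C=C(c1cc(OC)c(OC)c(OC)c1)c1ccc(OC)cc1NC(=O)CN` stands to compound 2 as compound 3 stands to compound 1: amino in place of hydroxy on a saturated chain carbon bound to a carbonyl carbon. The place of the change is worded identically in both pairs, so this is the same change on a second core. Because the first pair showed a 2.0-fold higher number from compound 1 to compound 3 (0.30 log units; within the scatter), a step of about the same size, a 2.0-fold higher number from compound 2 to compound 4 (0.30 log units; within the scatter), is expected from compound 2 to compound 4. On that basis compound 4 is estimated to give 60 nM in this assay, with a plausible range from 25 nM to 150 nM.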

Compound 4, half-maximal inhibitory concentration: 30 nM
For compound 4 the middle estimate is 2.0-fold (0.30 log units) above the measured one, and the stated range covers the measured number.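

In this assay, amino in place of hydroxy on the core of compound 2 gives no change at the digits printed from compound 2 to compound 4 (within the scatter), so on this core the two compounds cannot be told apart. Set beside the same change on the core of compound 1, the two steps do not differ by more than repeated measurements of this kind would: the same change on two cores in this assay, a 2.0-fold higher number (0.30 log units; within the scatter) from compound 1 to compound 3 and no change at the digits printed (within the scatter) from compound 2 to compound 4, 2.0-fold (0.30 log units) apart, within the scatter of two such steps. This shows that the change behaves alike on these two cores as far as the scatter allows, but it does not show that the two cores respond identically, and two pairs, with neither step beyond the scatter, say nothing about how the change would behave on a third core.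

The compounds shown leave open how either core would take a different end to this chain, such as a dimethylamino group or a carboxylic acid, or a longer chain carrying the amino. They also leave open whether the same picture holds in other cell lines.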